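The source may hold more compounds than are shown below. What is called first, only, known or untested is meant among the compounds shown, and "the series" means these compounds.

Measured compounds:
compound 1 `Nc1cc(N)c2nc(-c3ccccc3)c(Oc3ccc(Cl)c(Cl)c3)nc2c1`, < 100000 nM
compound 2 `COc1cc(CNc2nc3cc(N)cc(N)c3nc2-c2ccccc2)cc(OC)c1OC`, 32400 nM
compound 3 `COc1ccc(CNc2nc3cc(N)cc(N)c3nc2-c2ccccc2)cc1`, 69200 nM

Working notes on the series. In a functional assay on SN12C cells (Homo sapiens) for inhibition, read by sulforhodamine B assay, with a stated time of 48 h (on this read-out higher numbers stand for lower toxicity in this test and lower numbers for higher toxicity in this test), compound 2 gives 32400 nM and compound 3 gives 69200 nM. For compound 1 only a limit is recorded, < 100000 nM, so compound 1 stands at the limit of < 100000 nM in this assay, at which 1 of the 3 values shown sits, and no number is known for it. The next compound is compound 4 `Nc1cc(N)c2nc(-c3ccccc3)c(Sc3ccc(Cl)c(Cl)c3)nc2c1`. Compound 4 differs from compound 1 by (3,4-dichlorophenyl)sulfanyl in place of 3,4-dichlorophenoxy on an aromatic carbon, in words (3,4-dichlorophenyl)sulfanyl in place of 3,4-dichlorophenoxy on an aromatic carbon. Among the compounds with values here, no two measured compounds differ in a single place, so no measured step can be drawn on here. The step expected in this assay from compound 1 to compound 4 is one that stays within the usual scatter, in no particular direction: a step that the limit leaves unreadable from compound 1 to compound 4. Compound 4 is estimated at 60000 nM, expected between 20000 nM and 100000 nM.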

Compound 4, concentration lethal to 50% of the cells: 64600 nM
Compound 4: middle estimate off by 1.1-fold (0.03 log units), on the low side, and the stated range covers the measured number.
By their numbers in this assay, from the lowest: compounds 2, 4 and 3 (each within the scatter of the next, the first and the last beyond it).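

No new step can be read from compound 1 to compound 4, because compound 1 carries only a limit: the limit of < 100000 nM in this assay, at which 1 of the 4 values shown sits. As far as these compounds go, how far (3,4-dichlorophenyl)sulfanyl in place of 3,4-dichlorophenoxy on an aromatic carbon moves the value in this assay stays open.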